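From a phenol to its acetate on a quaternary ammonium

The source may report more compounds than this note shows. Statements on the series, on what has been measured and on what is new or still open speak of the compounds shown alone.

For the measured compounds named here, compound 1 `C=CC[N+](C)(C)c1cccc(O)c1` is the only compound here with a measured number: in a functional assay with Cavia porcellus as the target (on this read-out lower numbers stand for stronger inhibition and higher numbers for weaker inhibition), compound 1 gives 13000 nM. Compound 2 `C=CC[N+](C)(C)c1ccc(OC)cc1` reaches only a limit of the assay, > 3000 nM, so its number is not known. This is the whole picture at present: the limit of > 3000 nM in this assay, at which 1 of the 2 values shown sits. Compound 3 `C=CC[N+](C)(C)c1cccc(OC(C)=O)c1` differs from compound 1 by acetyl in place of hydrogen on an oxygen on an aromatic ring. Going by the values given here, no step between measured compounds is available, so the expectation rests on compound 1 and its value of 13000 nM. The step is expected to stay small, at most a modest weakening, a 1.2-fold higher number from compound 1 to compound 3 (0.09 log units; within the scatter). Compound 3 is therefore estimated at 16000 nM, within 4000 nM to 60000 nM.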

Compound 3, half-maximal inhibitory concentration: 3870 nM
Estimate against measurement, compound 3: 4.1-fold (0.62 log units) above; measured number below the stated range.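

Replacing the hydroxy group with an acetoxy group is not a neutral change at this position. In this assay it gives a 3.4-fold lower number from compound 1 to compound 3 (0.53 log units; beyond the scatter), and a lower number here means stronger inhibition, so the hydrogen on this oxygen is not required for activity and the added acetyl is tolerated. Compound 2 remains a limit of the assay and adds no number to this comparison: the limit of > 3000 nM in this assay, at which 1 of the 3 values shown sits.

As far as these compounds go, it remains open whether a longer acyl chain such as butyryl on this oxygen would strengthen inhibition further. An amine in place of the oxygen is also untested among these compounds.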